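The compounds below may be only part of what the source reports. "The series", "measured", "known", "first", "only" and "open" are said of these compounds alone.

Of the compounds shown here, three sharing one core have been measured in an assay on Sf9 cells for inhibition of 1-acyl-sn-glycerol-3-phosphate acyltransferase beta (Homo sapiens); on this read-out lower numbers stand for stronger inhibition and higher numbers for weaker inhibition. Compound 1 `CCOc1ccc(Br)cc1-c1cc(Nc2ccc(B(O)O)cc2)nc(N)n1` gives 91 nM in this assay, compound 2 `CCOc1ccc(Br)cc1-c1cc(Nc2ccc(C#N)cc2)nc(N)n1` gives 17 nM, and compound 3 `CCOc1ccc(Br)cc1-c1cc(Nc2ccc(C(=O)NO)cc2)nc(N)n1` gives 88 nM. Compound 3 thus stands second highest of the three numbers: its value and that of compound 1 lie within the scatter of each other, while the step of a 5.2-fold higher number from compound 2 to compound 3 (0.71 log units; beyond the scatter) lies beyond it. Compound 4 `CCOc1ccc(Br)cc1-c1cc(Nc2ccc(C(C)=O)cc2)nc(N)n1` differs from compound 3 by methyl in place of hydroxyamino on a carbonyl carbon. Among the compounds with values here, no measured step exchanges a group on a carbonyl carbon, and no measured compound carries an acetyl group, so the expectation rests on the spread of the three values. Of the measured changes on the same aromatic carbon, a 5.4-fold lower number from compound 1 to compound 2 (0.73 log units; beyond the scatter) and a 5.2-fold higher number from compound 2 to compound 3 (0.71 log units; beyond the scatter) were modest and beyond the scatter, while a 1.0-fold lower number from compound 1 to compound 3 (0.01 log units; within the scatter) was within it. Compound 4 is therefore expected to fall inside that spread, which means an estimated step of a 2.2-fold lower number from compound 3 to compound 4 (0.34 log units; beyond the scatter) that may not reach beyond the scatter. The estimate for compound 4 is 40 nM, with a range from 15 nM to 110 nM.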

Compound 4, half-maximal inhibitory concentration: 34 nM
Compound 4: the middle estimate sits 1.2-fold (0.07 log units) above what was measured; low and high end bracket the measured number.
By their numbers in this assay, from the lowest: compounds 2 and 4 (each within the scatter of the next); then compounds 3 and 1 (each within the scatter of the next).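

Exchanging hydroxyamino for methyl on the carbonyl carbon, with that carbonyl kept in place, gives a 2.6-fold lower number from compound 3 to compound 4 (0.41 log units; beyond the scatter), so in this assay the read-out responds to the group on this carbon and not only to the presence of a carbonyl. Acetyl also separates from the boronic acid, with a 2.7-fold lower number from compound 1 to compound 4 (0.43 log units; beyond the scatter), whereas a 2.0-fold higher number from compound 2 to compound 4 (0.30 log units; within the scatter) leaves acetyl and nitrile indistinguishable on these numbers. No accompanying data explain these steps.

From the compounds shown here alone, whether a longer chain such as ethyl, or an amine, on the same carbonyl carbon would stay level with methyl remains open. Also open, going by these compounds, is how a carboxylic acid on the aromatic carbon would compare with the hydroxycarbamoyl group of compound 3.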